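The compounds below may be only part of what the source reports. "The series", "measured", "known", "first", "only" and "open" are said of these compounds alone.

In an ADME assay on WI-38 cells (Homo sapiens) for cytotoxicity, read by MTT assay, with a stated time of 3 days (a higher number here means a weaker inhibitor, a lower number a stronger inhibitor), the measured compounds stand as follows.
Compound 1, `CCCCc1ccc(C#Cc2cn(C/C=C/CN3C(=O)c4ccccc4C3=O)c(=O)[nH]c2=O)cc1`, gives 40000 nM.
Compound 3, `O=C1c2ccccc2C(=O)N1C/C=C/Cn1cc(C#CCCc2ccccc2)c(=O)[nH]c1=O`, gives 31000 nM.
Compound 2, `O=C1c2ccccc2C(=O)N1C/C=C\Cn1cc(C#CCCc2ccccc2)c(=O)[nH]c1=O`, reaches only the limit of > 100000 nM, so no number is known for it.

Compound 4, `CCCCc1ccc(C#Cc2cn(C/C=C\CN3C(=O)c4ccccc4C3=O)c(=O)[nH]c2=O)cc1`, has not yet been measured in this assay. It differs from compound 2 by 4-butylphenyl in place of phenethyl on a triple-bonded carbon. The same change, (4-butylphenyl in place of phenethyl on a triple-bonded carbon), is seen between compound 3 and compound 1, where it made a 1.3-fold higher number from compound 3 to compound 1 (0.11 log units; within the scatter). Compound 2 and compound 3 have the same core and differ only by the two compounds have the same atoms and bonds and differ only in configuration as drawn: 1 of 1 stereo elements differ; a double bond is drawn E in compound 3 and Z in compound 2; the step of an at least 3.2-fold lower number from compound 2 to compound 3 (0.50 log units; beyond the scatter) rests on the limit of > 100000 nM in this assay, at which 1 of the 3 values shown sits, and on (the fact that compounds 2 and 3 differ only in the configuration as drawn). Compound 2 thus stands at the edge of what this measurement can report.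

For compound 4, an estimated step that the limit leaves unreadable from compound 2 to compound 4 is expected, resting on the step of a 1.3-fold higher number from compound 3 to compound 1 (0.11 log units; within the scatter) that the same change made. Compound 4 is therefore estimated at 130000 nM, between 50000 nM and 400000 nM, and it is expected that this assay may again report only a limit for compound 4.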

Compound 4, half-maximal inhibitory concentration: 17000 nM
For compound 4 the middle estimate is 7.6-fold (0.88 log units) above the measured one, outside the stated range (below it).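

In this assay, 4-butylphenyl in place of phenethyl on a triple-bonded carbon gave an at least 5.8-fold lower number from compound 2 to compound 4 (0.76 log units; beyond the scatter) and so did not repeat the step it made on the other core: the same change on two cores in this assay, a 1.3-fold higher number (0.11 log units; within the scatter) from compound 3 to compound 1 and an at least 5.8-fold lower number (0.76 log units; beyond the scatter) from compound 2 to compound 4, at least 7.5-fold (0.88 log units) apart, beyond the scatter of two such steps. Compound 2 stands only at a limit: the limit of > 100000 nM in this assay, at which 1 of the 4 values shown sits. With 4-butylphenyl the Z form gives the lower number in a 2.4-fold lower number from compound 1 to compound 4 (0.37 log units; beyond the scatter) and with phenethyl the E form does, which shows that in these four compounds the step taken by this change goes with the configuration drawn at the double bond, though it does not show why: the fact that compounds 1 and 4 differ only in the configuration as drawn.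

The compounds shown leave open whether a longer chain or an amine in place of 4-butylphenyl would follow the same split between the E and Z forms. They also leave open what a saturated chain in place of the double bond would do to the step.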